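Aromatase inhibition: from compound 1 to compound 4

The source may hold more compounds than are shown below. What is called first, only, known or untested is meant among the compounds shown, and "the series" means these compounds.

Measured in an assay on isolated protein for inhibition of Aromatase (Homo sapiens), read by fluorescence, using NADPH, with a stated time of 30 min, tested at 50 uM (a lower number here means less inhibition, a higher number more inhibition at the concentration tested (going by the name of the read-out)), so far:

compound 1, `Brc1ccc(-c2cc3ccccc3[nH]2)cc1`, gives 4.8%
compound 2, `COCn1c(-c2ccccc2)cc2ccccc21`, gives 20.2%
compound 3, `Cn1c(-c2ccc(Cl)c(Cl)c2)cc2cc([N+](=O)[O-])ccc21`, gives 34%

Compound 1 stands lowest of the three numbers in this assay. The nearest of the other two is compound 2, whose value lies higher by a margin beyond the usual scatter; compound 3 lies furthest from compound 1, also beyond the scatter. Compounds 2 and 3 differ from compound 1 in several places at once, so none of these pairs isolates a single change.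

The next compound, compound 4, `Nc1ccc(-c2cc3ccccc3[nH]2)cc1`, differs from compound 1 in one place: amino in place of bromo on an aromatic carbon. For the measured compounds named here, no measured pair shows this particular exchange, so the size of the step is not anchored by earlier data. Given that compound 1 sits at 4.8%, a small upward movement or none beyond the scatter is expected, a number 5.2 percentage points higher from compound 1 to compound 4 (within the scatter). Compound 4 is accordingly estimated at 10% in this assay, with a range from 0% to 25%.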

Compound 4, a percentage reported as inhibition, at one concentration (the size of the read-out at that concentration, not a potency): 46.2%
For compound 4 the middle estimate is 36.2 percentage points below the measured one; measured number above the stated range.
By their numbers in this assay, from the lowest: compound 1; then compound 2; then compound 3; then compound 4.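

Amino in place of bromo on an aromatic carbon, para to a group of 9 heavy atoms, gives a number 41.4 percentage points higher from compound 1 to compound 4 (beyond the scatter) in this assay. For the compounds shown here, this is the first step that isolates a single place, and it shows that this position is far from indifferent to its substituent: exchanging one heavy atom for another, with no ring added and no net charge on either side, moves the read-out by a large margin. Nothing available here accounts for the size of this step.

As far as these compounds go, whether the step reflects the arrival of amino or the departure of bromo stays open, and a hydroxyl, a methoxy group or a dimethylamino group on the same carbon would help to separate the two. Also open, from the compounds shown here alone, is whether the same exchange gives a step of similar size in compounds carrying further changes on the core.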